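The compounds below may be only part of what the source reports. "The series", "measured", "known", "first", "only" and "open" are said of these compounds alone.

Compound 2 `C/N=C(\NC#N)NCCSCn1nc(-c2ccc(Cl)cc2)ccc1=O` in a functional assay on the whole organism (stomach) for inhibition, with Rattus norvegicus as the target, with a stated time of 4 h (a lower number here means that less compound is needed, a higher number that more compound is needed for the effect), gives < 39.1 mg/kg, which is a limit of the assay and not a number (the limit of < 39.1 mg/kg in this assay, at which 1 of the 2 values shown sits). Compound 1 `C/N=C(\NC#N)NCCSCn1nc(-c2ccccc2)ccc1=O` in this assay gives < 30.5 mg/kg, also a limit (the limit of < 30.5 mg/kg in this assay, at which 1 of the 2 values shown sits). The step that the two limits leave unreadable from compound 1 to compound 2 is thus not readable. Compound 3 `C/N=C(\NC#N)NCCSCn1nc(-c2ccc(C)cc2)ccc1=O` differs from compound 2 by methyl in place of chloro on an aromatic carbon. Among the measured compounds shown here, no measured step bears on this change with a readable size, so no shift beyond the scatter is expected; the estimated step that the limit leaves unreadable from compound 2 to compound 3 is small. Compound 3 in this assay is expected near 20 mg/kg, in the range 5 mg/kg to 60 mg/kg.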

Compound 3, dose for half-maximal effect: < 53.8 mg/kg
Compound 3 gave a limit, no number; the forecaster's own chance of this, stated with the estimate: 50%; the middle value is on the limit's open side.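

Among the compounds shown here, compound 1, compound 2 and compound 3 all stand as limits and not numbers, and no step among them can be read. From the compounds shown here alone, whether hydrogen, chloro or methyl on the aromatic carbon changes the required dose stays open.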